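The source may hold more compounds than are shown below. What is called first, only, known or untested is meant among the compounds shown, and "the series" means these compounds.

Within the data shown here, compound 1 `COc1cc2ncnc(NNC(=S)NC(=O)c3ccccc3OC)c2cc1OC` is the one compound of this small set that gives a numerical result. In a functional assay on KB cells (Homo sapiens) for cytotoxicity, read by MTT assay, with a stated time of 72 h (a higher number here means a weaker inhibitor, a lower number a stronger inhibitor), compound 1 gives 3850 nM. Compound 2 `COc1ccccc1C(=O)NC(=S)NNc1ncnc2ccccc12` lacks the two methoxy groups on the shared core. In this assay compound 2 gives only a limit of the assay, > 50000 nM, and no number. Among the measured compounds shown here, compound 1 therefore stands alone as the only measured value, with the other result sitting at the limit described in the limit of > 50000 nM in this assay, at which 1 of the 2 values shown sits. Compound 3 `COc1cc2ncnc(NNC(=S)NC(=O)c3cccc(Cl)c3)c2cc1OC` keeps the core and the thiosemicarbazide linker of compound 1 and changes the aroyl group: 3-chlorophenyl in place of 2-methoxyphenyl on a carbonyl carbon. For the measured compounds named here, no measured pair shows what this kind of exchange does, so the expectation rests on compound 1 alone. The step from compound 1 to compound 3 is expected to be a 1.0-fold higher number from compound 1 to compound 3 (0.02 log units; within the scatter), which is not beyond the usual scatter in either direction. Compound 3 is estimated at 4000 nM in this assay, within a range from 1500 nM to 12000 nM.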

Compound 3, half-maximal inhibitory concentration: 4830 nM
For compound 3 the middle estimate is 1.2-fold (0.08 log units) below the measured one; the range from low to high includes it.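

In this assay, the exchange of the aroyl group, 3-chlorophenyl in place of 2-methoxyphenyl on a carbonyl carbon, gives a 1.3-fold higher number from compound 1 to compound 3 (0.10 log units; within the scatter). Among these compounds, this is the first measured change at this position, and it shows that the two aryl groups cannot be told apart here, so a methoxy group on that ring is not needed for a numerical result with the dimethoxy-bearing core of compound 1. The only limit in the set remains that of compound 2: the limit of > 50000 nM in this assay, at which 1 of the 3 values shown sits.

The compounds shown leave open whether this position would still give a similar value with a plain alkyl chain in place of the ring, or with an amine or a carboxylic acid on the ring. They also do not show how 3-chlorophenyl behaves on the core without its two methoxy groups.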